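Swapping Bromo for Phenyl: What the Flat Step Predicts

The source may report more compounds than this note shows. Statements on the series, on what has been measured and on what is new or still open speak of the compounds shown alone.

Two compounds share one core and differ only in a single group on an aromatic carbon. Compound 1 `CC(C)(C)Cc1c(/C=C/c2ccc(Cl)cc2)sc(N)c1C(=O)c1ccc(Cl)cc1` carries a 2-(4-chlorophenyl)ethenyl group there, and in an assay on CHO cells for displacement of a labelled ligand from adenosine receptor A1 (Homo sapiens), read by scintillation counting, tested at 10 uM (a higher number here means more inhibition at the concentration tested (going by the name of the read-out), a lower number less inhibition), compound 1 gives 1%. Compound 2 `CC(C)(C)Cc1c(Br)sc(N)c1C(=O)c1ccc(Cl)cc1` carries bromo in its place, and in this assay compound 2 gives 1%. The step of no change at the digits printed from compound 1 to compound 2 (within the scatter) shows that this exchange left the read-out unchanged, so compound 2 stands level with compound 1 at the digits shown, with essentially no inhibition. Compound 3 `CC(C)(C)Cc1c(-c2ccccc2)sc(N)c1C(=O)c1ccc(Cl)cc1` is the next exchange at the same aromatic carbon: phenyl in place of bromo on an aromatic carbon. For the measured compounds named here, the only measured step at this position was flat, so for compound 3 the expected step of a number 2 percentage points higher from compound 2 to compound 3 (within the scatter) in this assay is none beyond the scatter. Compound 3 is therefore estimated at 3%, within a range from -5% to 15%.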

Compound 3, a percentage reported as inhibition, at one concentration (the size of the read-out at that concentration, not a potency): 1%
Compound 3: middle estimate off by 2 percentage points, on the high side; the measured number falls inside the stated range.
By their numbers in this assay, from the lowest: compounds 1, 2 and 3 (each within the scatter of the next).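

In this assay, phenyl in place of bromo brings no change at the digits printed from compound 2 to compound 3 (within the scatter), and phenyl in place of 2-(4-chlorophenyl)ethenyl brings no change at the digits printed from compound 1 to compound 3 (within the scatter). This position on the shared core has now held three different groups, a single bromine atom, a phenyl ring attached directly and a chlorophenyl ring held out on an ethenyl link, and none of them separates from the others in this read-out, all of them showing almost no inhibition. Nothing measured here offers an explanation for this flat result.

Going by these compounds, whether a carboxylic acid or an amine at this aromatic carbon would lift the read-out remains open. Also open, on these data alone, is whether these exchanges would stay flat with an ethyl chain in place of the neopentyl group.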